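From 4-carboxyphenyl to anilino on the shared core

The source may report more compounds than this note shows. Statements on the series, on what has been measured and on what is new or still open speak of the compounds shown alone.

Measured so far in a functional assay on MCF7 cells (Homo sapiens) for cytotoxicity, read by sulforhodamine B assay, with a stated time of 24 h; a higher number here means a weaker inhibitor, a lower number a stronger inhibitor
compound 1 `O=C1Nc2ccc(S(=O)(=O)N3CCOCC3)cc2/C1=N/c1ccc(Br)cc1` at 44800 nM
compound 2 `O=C1Nc2ccc(S(=O)(=O)N3CCOCC3)cc2/C1=N/c1ccc(C(=O)O)cc1` at 26700 nM

Compound 2 (at 26700 nM in this assay) lies within the scatter of compound 1 (at 44800 nM) and the two numbers cannot be ranked. Compound 3 `O=C1Nc2ccc(S(=O)(=O)N3CCOCC3)cc2/C1=N/Nc1ccccc1` has not been measured yet. The change from compound 2 is anilino in place of 4-carboxyphenyl on a double-bonded nitrogen and in words it is anilino in place of 4-carboxyphenyl on a double-bonded nitrogen.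

Going by the values given here, only one measured step bears on this, and only indirectly. That step, carboxy in place of bromo on an aromatic carbon, is a 1.7-fold lower number from compound 1 to compound 2 (0.22 log units; within the scatter) and stays within the scatter. Among the compounds with values here, it does not test the replacement of the whole 4-carboxyphenyl, and no measured compound carries anilino, so the data offer no direction for the change. A shift beyond the scatter in this assay is therefore not expected either way. The estimated step is a 1.1-fold lower number from compound 2 to compound 3 (0.03 log units; within the scatter) and this is expected to stay within the scatter. Compound 3 is estimated at 25000 nM (expected range 8000 nM to 70000 nM).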

Compound 3, half-maximal inhibitory concentration: 30300 nM
Compound 3: middle estimate off by 1.2-fold (0.08 log units), on the low side; measured number inside the range.
By their numbers in this assay, from the lowest: compounds 2, 3 and 1 (each within the scatter of the next).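

In this assay, anilino in place of 4-carboxyphenyl on a double-bonded nitrogen gives a 1.1-fold higher number from compound 2 to compound 3 (0.05 log units; within the scatter), and anilino in place of 4-bromophenyl at the same place gives a 1.5-fold lower number from compound 1 to compound 3 (0.17 log units; within the scatter). The earlier step changed only the group on the aromatic carbon, whereas these two steps exchange the whole group on the double-bonded nitrogen, including the atom that joins its aromatic ring to the shared core, and neither step moves the number beyond the scatter. All three groups at this place, 4-bromophenyl, 4-carboxyphenyl and anilino, therefore give numbers that cannot be ranked, and no accompanying measurement offers an explanation for this.

The compounds shown leave open whether a group of another kind on this nitrogen, such as an aliphatic amine or a longer carbon chain ending in a phenyl ring, would give a step beyond the scatter. Going by these compounds alone, they also leave open whether a carboxylic acid or a bromine on the anilino ring would do so, since the only anilino compound, compound 3, carries neither.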